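The source may hold more compounds than are shown below. What is called first, only, known or untested is meant among the compounds shown, and "the series" means these compounds.

Measured so far:

compound 1 `Nc1nc(N)c2nc(CCc3ccc(C(=O)NC(CCC(=O)O)C(=O)O)s3)cnc2n1` — 3.1 nM
compound 2 `CCC(Cc1cnc2nc(N)nc(N)c2n1)c1ccc(C(=O)NC(CCC(=O)O)C(=O)O)s1` — 1.6 nM
compound 3 `Nc1nc(N)c2nc(CCc3ccc(C(=O)NC(CCC(=O)O)C(=O)O)cn3)cnc2n1` — 36 nM

All three were tested in a functional assay (Homo sapiens); on this read-out higher numbers stand for weaker inhibition and lower numbers for stronger inhibition. Compound 3 stands highest of the three numbers, so it is the weakest inhibitor here: compound 1 lies well beyond the scatter below it, and compound 2 lies further below still. Compound 3 differs from compound 1 only in the aromatic ring that carries the amide, so those two values show what that ring swap costs on its own.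

Compound 4 `CCC(Cc1cnc2nc(N)nc(N)c2n1)c1ccc(C(=O)NC(CCC(=O)O)C(=O)O)cn1` is the next step from compound 3, and the change is ethyl in place of hydrogen on a saturated chain carbon bound to an aromatic carbon and a saturated chain carbon. The same change has already been made once, within this set, between compound 1 and compound 2: there it gave a 1.9-fold lower number from compound 1 to compound 2 (0.29 log units; within the scatter), which is too small to count as a real shift. Nothing in these data suggests the ethyl should behave differently on the core of compound 3, so the expected outcome in this assay is at most a modest drop in the number, in the direction of stronger inhibition, and quite possibly no change beyond the scatter.

Compound 4 is therefore estimated at 20 nM, with a plausible range from 8 nM to 55 nM, which corresponds to an expected step of a 1.8-fold lower number from compound 3 to compound 4 (0.26 log units; within the scatter).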

Compound 4, half-maximal inhibitory concentration: 35 nM
Estimate against measurement, compound 4: 1.8-fold (0.24 log units) below; measured number inside the range.
By their numbers in this assay, from the lowest: compounds 2 and 1 (each within the scatter of the next); then compounds 4 and 3 (each within the scatter of the next).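

In this assay, ethyl in place of hydrogen on this saturated chain carbon gives a 1.0-fold lower number from compound 3 to compound 4 (0.01 log units; within the scatter), so on a second core the change again moves the number by no more than repeated measurements would. The earlier pair alone could not show this, since a single small step might have been peculiar to the core of compound 1, but now the change leaves the number within the scatter on both cores, and the two steps agree with each other: the same change on two cores in this assay, a 1.9-fold lower number (0.29 log units; within the scatter) from compound 1 to compound 2 and a 1.0-fold lower number (0.01 log units; within the scatter) from compound 3 to compound 4, 1.9-fold (0.28 log units) apart, within the scatter of two such steps The difference between the cores also remains with ethyl present, as compound 2 gives 1.6 nM while compound 4 gives 35 nM.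

The compounds shown carry only hydrogen or ethyl at this carbon, so it remains open whether a longer chain, an amine or a carboxylic acid placed there would move the number beyond the scatter. From the compounds shown here alone, both steps also come from this assay alone, so how this change reads in any other kind of measurement remains unknown.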